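Chain extension on the amide side of the shared core

This account rests on a few compounds, and the source may have more. Where it says the series, first, only, none or still open, it means among the compounds named here.

Compound 1 `O=C(CCc1ccccc1)Nc1nc2ccccc2c(=O)s1` carries a phenyl on a saturated chain two bonds from the carbonyl, attached through an amide to the shared core. Among the measured compounds shown here, in an assay on membranes from brain for displacement of a labelled ligand from adenosine receptor A1 (Rattus norvegicus), read by scintillation counting, with a stated time of 90 min (a lower number here means a stronger inhibitor, a higher number a weaker inhibitor), compound 1 gives 422 nM, the only numeric value among the three measured compounds. Compound 2 `O=C(CCCc1ccccc1)Nc1nc2ccsc2c(=O)s1` has a longer chain and a different core; in this assay compound 2 reaches only the limit >= 10000 nM, which is a limit of the assay and not a number. Compound 3 `COc1cccc(C#CC(=O)Nc2nc3ccccc3c(=O)s2)c1` has a methoxyphenyl joined through an alkyne to the carbonyl; in this assay compound 3 likewise gives only the limit > 10000 nM, again a limit and not a number. For the measured compounds named here, no pair of measured compounds differs in one place, so no measured step is available, and compound 1 stands alone as the reference.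

Compound 4 `O=C(CCCc1cccc(Cl)c1)Nc1nc2ccccc2c(=O)s1` is the next candidate. Relative to compound 1 the change is 3-chlorobenzyl in place of phenyl on a saturated chain carbon, two bonds along the chain from a carbonyl carbon. The expectation is a step toward weaker binding of about a 4.7-fold higher number from compound 1 to compound 4 (0.68 log units; beyond the scatter), beyond the scatter, with a real chance that only a limit is returned. For compound 4 in this assay the estimate is 2000 nM, within 500 nM to 10000 nM.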

Compound 4, inhibition constant: 898 nM
Compound 4: the middle estimate sits 2.2-fold (0.35 log units) above what was measured; the range from low to high includes it.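

In this assay, among the compounds shown here, 3-chlorobenzyl in place of phenyl on a saturated chain carbon, two bonds along the chain from a carbonyl carbon, gives the first step that can be read: a 2.1-fold higher number from compound 1 to compound 4 (0.33 log units; beyond the scatter). The step is modest but beyond the scatter, so this position accepts the larger group at some cost and still returns a number rather than a limit, on the same shared core. The change brings in both an extra chain carbon and a chlorine at once, and nothing measured here gives a cause for the weaker binding or assigns the step to either part.

What the compounds shown leave open is how much of the step belongs to the chlorine and how much to the extra carbon, a question that plain benzyl at this position would address directly. Also open, on these data alone, is how this position responds to other groups on the aromatic ring, such as an amine or a carboxylic acid, or to a longer chain on the same core.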